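A few compounds are considered here, and "the series" means these few. Any claim that something is new, unique, unknown or untested is made for them only; others in the source may bear on it.

In a functional assay on MDA-MB-231 cells (Homo sapiens) for antiproliferative activity, read by MTT assay, with a stated time of 72 h (a higher number here means a weaker inhibitor, a lower number a stronger inhibitor), two compounds sharing one core have been measured so far. Compound 1 `O=C(CCc1cccc2c1B(O)OC2)Nc1cccc(-c2ccc(Cl)cc2)c1` gives 260 nM in this test, and compound 2 `COc1ccc(-c2cccc(NC(=O)CCc3cccc4c3B(O)OC4)c2)cc1` gives 88 nM as the lower of the two numbers, which makes it the stronger inhibitor of the pair. Compound 3 `O=C(CCc1cccc2c1B(O)OC2)Nc1cccc(-c2ccc(OC(F)(F)F)cc2)c1` has not yet been measured in this assay and differs from compound 2 by trifluoromethyl in place of methyl on an oxygen on an aromatic ring, which reads as methoxy to trifluoromethoxy (trifluoromethyl in place of methyl on an oxygen on an aromatic ring). Going by the values given here, only one measured step bears on this change, the swap of chloro for methoxy at the same place, which gave a 3.0-fold lower number from compound 1 to compound 2 (0.47 log units; beyond the scatter) as a modest shift. That single pair shows that the number responds to the group there, but it says nothing directly about trifluoromethoxy. Compound 3 gives up the methoxy group, so part of that gain is expected to be lost. The step expected is a 2.0-fold higher number from compound 2 to compound 3 (0.31 log units; beyond the scatter) in the direction of a higher number, similar to or smaller than the measured one, though this is uncertain. For compound 3 an estimated 180 nM is expected, with an estimated range of 70 nM to 500 nM around it.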

Compound 3, half-maximal inhibitory concentration: 640 nM
The estimate for compound 3 lay 3.6-fold (0.55 log units) below the measured number; measured number above the stated range.
By their numbers in this assay, from the lowest: compound 2; then compound 1; then compound 3.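

In this assay, replacing the methyl on the oxygen with trifluoromethyl gives a 7.3-fold higher number from compound 2 to compound 3 (0.86 log units; beyond the scatter) and so does more than give back the gain seen on going from chloro to methoxy. Trifluoromethoxy also falls on the far side of chloro, with a 2.5-fold higher number from compound 1 to compound 3 (0.39 log units; beyond the scatter) as the step, so the three groups do not simply divide into those with and without an oxygen on the aromatic carbon: compound 2 has the lowest number and compound 3 the highest, although both carry that oxygen. Going by these compounds alone, the earlier pair showed only that the number responds to the group at this place, whereas this result shows that a change confined to the group on the oxygen can move the number further than the chloro to methoxy swap did, and no measurement available here accounts for that order.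

The compounds shown leave open how an ethoxy group, with its longer chain on the oxygen, or a hydroxyl group or an amine at the same place would compare with the methoxy group of compound 2. They also leave open whether the same order of methoxy, chloro and trifluoromethoxy would hold with any change to the shared core or the amide chain.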